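The compounds below may be only part of what the source reports. "The series", "measured", "known", "first", "only" and "open" are said of these compounds alone.

Compound 1 `COc1cccc(/C=C/C(=O)Nc2cc(OC)c(OC)c(OC)c2)c1`: 44100 nM
Compound 2 `C=C(Br)C(=O)Nc1cccc(/C=C/C(=O)Nc2cccc3ccccc23)c1`: 6500 nM
Compound 3 `C=C(Br)C(=O)Nc1cccc(/C=C/C(=O)Nc2ccc(F)cc2)c1`: 36600 nM

In a functional assay on HT-29 cells (Homo sapiens) for inhibition, read by MTT assay, with a stated time of 72 h (a higher number here means a weaker inhibitor, a lower number a stronger inhibitor), compound 3 gives 36600 nM. This lies within the usual scatter of compound 1 at 44100 nM, so the two cannot be told apart. Compound 2, at 6500 nM, is a stronger inhibitor than compound 3 by a margin beyond the scatter.

Compound 4 `C=C(Br)C(=O)Nc1cccc(/C=C/C(=O)Nc2ccc(C)cc2)c1` changes compound 3 in one place: methyl in place of fluoro on an aromatic carbon, para to a large group. For the measured compounds named here, no two measured compounds differ in only one place, so the data do not show how large such a swap can be. The expected 1.5-fold lower number from compound 3 to compound 4 (0.17 log units; within the scatter) is small, towards a lower number, and within the scatter. For compound 4 the estimated value is 25000 nM, with an expected range from 10000 nM to 60000 nM.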

Compound 4, half-maximal inhibitory concentration: 1200 nM
The estimate for compound 4 lay 21-fold (1.32 log units) above the measured number; the measured number lies below the stated range.
By their numbers in this assay, from the lowest: compound 4; then compound 2; then compounds 3 and 1 (each within the scatter of the next).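

Swapping fluoro for methyl on the aromatic carbon para to a large group gives a 31-fold lower number from compound 3 to compound 4 (1.48 log units; beyond the scatter) in this assay. For the compounds shown here, this shows that exchanging one heavy atom at this single place can shift the number by a large margin, which no earlier pair of compounds could reveal. Nothing measured here explains the size of this step. Still open, from the compounds shown here alone, is whether methyl is unusual at this place or whether chloro, ethyl or an amine there would give a similar number. Going by these compounds, it is also open whether the same swap would have as large an effect on a different core.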